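Notes on the step from compound 2 to compound 3

This account rests on a few compounds, and the source may have more. Where it says the series, first, only, none or still open, it means among the compounds named here.

Measured so far in an ADME assay for permeability, using PAMPA, at pH 7.4; on this read-out lower numbers stand for lower permeability and higher numbers for higher permeability
- compound 1 `O=C(Nc1nc2ccc(Cl)cc2s1)c1cc([N+](=O)[O-])ccc1Cl` at 138 10^-6 cm/s
- compound 2 `O=C(Nc1nc(-c2ccc(Cl)cc2)cs1)c1cc([N+](=O)[O-])ccc1Cl` at 3 10^-6 cm/s

Compound 2 holds the lower of the two numbers, and its gap to compound 1 lies beyond the scatter. The two differ in more than one place, so that gap sizes no single change. Compound 3 `O=C(Nc1nc(-c2cccc(F)c2)cs1)c1cc([N+](=O)[O-])ccc1Cl` has 3-fluorophenyl in place of 4-chlorophenyl on an aromatic carbon. Within the data shown here, no measured pair yet shows what such a swap does in this assay for this series. The value of compound 2 (3 10^-6 cm/s) sits far under that of compound 1 (138 10^-6 cm/s), which leaves room upward, so a modest rise is expected, though a result within the scatter remains possible. The expected change is a 2.3-fold higher number from compound 2 to compound 3 (0.37 log units; beyond the scatter) (an estimate). For compound 3 the estimated value is 7 10^-6 cm/s (expected range 2 10^-6 cm/s to 35 10^-6 cm/s).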

Compound 3, apparent permeability: 3 10^-6 cm/s
Estimate against measurement, compound 3: 2.3-fold (0.37 log units) above, within the range that was stated.
By their numbers in this assay, from the lowest: compounds 2 and 3 (each within the scatter of the next); then compound 1.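

In this assay, among these compounds, the first step that changes a single place reads no change at the digits printed from compound 2 to compound 3 (within the scatter) for 3-fluorophenyl in place of 4-chlorophenyl on the aromatic carbon next to the ring nitrogen. At this position, then, the halogen and its place on the phenyl ring can both change without separating the two compounds on this read-out, although the swap alters two features at once and the step cannot assign anything to either one alone. Nothing available gives a measured property that would account for this result.

Going by these compounds, whether an unsubstituted phenyl, an amine or a carboxylic acid on this aromatic carbon would move the number remains open. Also open, on these data alone, is how far the number responds to changes elsewhere on the shared core, including the nitro group.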